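Replacing furan-2-yl with methyl on the shared core

The compounds below may be only part of what the source reports. "The series", "measured", "known", "first", "only" and "open" are said of these compounds alone.

Measured in an ADME assay on BJ cells (Homo sapiens), read by MTT assay, with a stated time of 3 days; a lower number here means a stronger inhibitor, a higher number a weaker inhibitor:
- compound 1 `c1csc(Sc2c[nH]c3ncnc(-c4cccs4)c23)c1`: 23400 nM
- compound 2 `c1coc(-c2ncnc3[nH]cc(Sc4cccs4)c23)c1`: 22100 nM

For the measured compounds named here, compound 2 stands level with compound 1, the only other compound measured, and the two values lie within the scatter of each other. The next compound, compound 3 `Cc1ncnc2[nH]cc(Sc3cccs3)c12`, keeps the core and the sulfur-linked thiophene but carries methyl in place of furan-2-yl on an aromatic carbon. Going by the values given here, only one measured step bears on this, a 1.1-fold lower number from compound 1 to compound 2 (0.02 log units; within the scatter), and it exchanged one five-membered aromatic ring for another. Among the compounds with values here, no measured step removes that ring, so this evidence is thin. In this assay, no step beyond the scatter is expected, with only a slight lean towards a higher number and wide uncertainty. The expected step is a 1.4-fold higher number from compound 2 to compound 3 (0.13 log units; within the scatter). For compound 3, the estimated value is 30000 nM, with an expected range of 12000 nM to 80000 nM.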

Compound 3, half-maximal inhibitory concentration: > 150000 nM
Compound 3: only a limit was reported; the forecaster's own chance of this, stated with the estimate: 25%; middle value at least 5.0-fold (0.69 log units) from the limit.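

For the compounds shown here, on this aromatic carbon, exchanging one five-membered aromatic ring for another left the number within the scatter, so the earlier compounds gave no sign that the group here matters in this assay. Removing the ring altogether does matter: methyl in place of furan-2-yl gives an at least 6.7-fold higher number from compound 2 to compound 3 (0.83 log units; beyond the scatter), and methyl in place of thiophen-2-yl gives an at least 6.4-fold higher number from compound 1 to compound 3 (0.80 log units; beyond the scatter). Compound 3 is reported only as a limit of the assay, not as a number: the limit of > 150000 nM in this assay, at which 1 of the 3 values shown sits.

The compounds shown cannot tell whether this carbon needs an aromatic ring in particular or simply a group bigger than methyl, and a phenyl ring, a propyl chain or an amine at this place would help separate those two readings. As far as these compounds go, whether the same holds when the sulfur-linked thiophene is replaced also remains open.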